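A few compounds are considered here, and "the series" means these few. Any claim that something is new, unique, unknown or untested is made for them only; others in the source may bear on it.

Measured compounds:
Compound 1, `COc1cc2c(Oc3ccc(NC(=O)c4nn(-c5ccccc5)c(=O)cc4C)cc3F)ccnc2cc1OCCCN1CCCC1`: 370 nM
Compound 2, `COc1cc2c(Oc3ccc(NC(=O)c4nn(-c5ccccc5C)c(=O)cc4C)cc3F)ccnc2cc1OCCCN1CCCC1`: 1300 nM

In a functional assay on A549 cells (Homo sapiens) for inhibition, read by MTT assay, with a stated time of 72 h (a higher number here means a weaker inhibitor, a lower number a stronger inhibitor), compound 1 gives 370 nM and compound 2 gives 1300 nM. Within the data shown here, compound 2 thus stands at the higher of the two numbers measured, with compound 1 as its only neighbour, and the step of a 3.5-fold higher number from compound 1 to compound 2 (0.55 log units; beyond the scatter) came from a methyl in place of hydrogen on an aromatic carbon. Compound 3, `COc1cc2c(Oc3ccc(NC(=O)c4nn(-c5ccccc5C(F)(F)F)c(=O)cc4C)cc3F)ccnc2cc1OCCCN1CCCC1`, carries the change (trifluoromethyl in place of methyl on an aromatic carbon). Among the measured compounds shown here, only the single step of a 3.5-fold higher number from compound 1 to compound 2 (0.55 log units; beyond the scatter) bears on this, and it shows that a methyl entering at that place raised the number in this assay beyond the scatter. Trifluoromethyl in place of that methyl is therefore expected to raise the number again, by a modest amount, a 1.9-fold higher number from compound 2 to compound 3 (0.28 log units; within the scatter). Compound 3 is accordingly estimated at 2500 nM in this assay, within a range of 800 nM to 8000 nM.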

Compound 3, half-maximal inhibitory concentration: 130 nM
Estimate against measurement, compound 3: 19-fold (1.28 log units) above, and the stated range ends above it.
By their numbers in this assay, from the lowest: compound 3; then compound 1; then compound 2.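

Trifluoromethyl in place of methyl on this aromatic carbon, ortho to a large group, gave a 10-fold lower number from compound 2 to compound 3 (1.00 log units; beyond the scatter) in this assay and so reversed the direction that the methyl had set. Measured against hydrogen at the same place, trifluoromethyl also gave a 2.8-fold lower number from compound 1 to compound 3 (0.45 log units; beyond the scatter) and thus took the number lower than the compound without a substituent there, whereas methyl had taken it higher. A substituent at this place is therefore not penalised as such, and among these three compounds the outcome depends on which group enters.

As far as these compounds go, whether a chlorine, a methoxy group or a nitrile at this place would follow methyl or trifluoromethyl stays open, as does the effect of trifluoromethyl elsewhere on that ring. Nothing at hand speaks to why the two groups part ways here.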